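This account rests on a few compounds, and the source may have more. Where it says the series, first, only, none or still open, it means among the compounds named here.

Measured so far:
compound 1 `CN(C)C(=O)c1cnc(C(=O)CCc2ccc(COc3ccccc3)cc2)o1`, with 6.7 nM in an assay for inhibition of Fatty-acid amide hydrolase 1 (Rattus norvegicus); a higher number here means a weaker inhibitor, a lower number a stronger inhibitor;
compound 2 `N#Cc1cccc(-c2cnc(C(=O)CCc3ccc(COc4ccccc4)cc3)o2)n1`, with 0.56 nM in this assay;
compound 3 `O=C(CCc1ccc(COc2ccccc2)cc1)c1ncco1`, with 25 nM in this assay.

Compound 3 gives the highest number of the three, and its steps to both other compounds are beyond the scatter. Compound 4 `O=C(CCc1ccc(COc2ccccc2)cc1)c1ncc(I)o1` differs from compound 3 in one place: iodo in place of hydrogen on an aromatic carbon. The two measured steps that touch this same carbon both show that placing a group there lowers the number: a 3.7-fold higher number from compound 1 to compound 3 (0.57 log units; beyond the scatter) and a 45-fold higher number from compound 2 to compound 3 (1.65 log units; beyond the scatter) read in reverse. Iodo is a single atom, unlike either of those groups, so a smaller shift is expected. For compound 4 the estimate is 10 nM, within 3 nM to 35 nM, meaning an expected 2.5-fold lower number from compound 3 to compound 4 (0.40 log units; beyond the scatter).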

Compound 4, inhibition constant: 4 nM
Estimate against measurement, compound 4: 2.5-fold (0.40 log units) above, and the stated range covers the measured number.
By their numbers in this assay, from the lowest: compound 2; then compounds 4 and 1 (each within the scatter of the next); then compound 3.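

In this assay, a single iodine atom on the ring carbon next to the ring oxygen is enough to shift the number clearly (a 6.3-fold lower number from compound 3 to compound 4 (0.80 log units; beyond the scatter)). Iodo and the much larger dimethylcarbamoyl group stay within the scatter of each other (a 1.7-fold lower number from compound 1 to compound 4 (0.22 log units; within the scatter)), whereas 6-cyanopyridin-2-yl keeps a clear edge over iodo (a 7.1-fold higher number from compound 2 to compound 4 (0.85 log units; beyond the scatter)), so only that ring-bearing group stands apart here. Nothing available explains these shifts.

From the compounds shown here alone, whether chloro, bromo or methyl at this carbon would behave like iodo remains open. So does the effect of an amine there.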